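Ring expansion at the amino group of compound 2

A few compounds are considered here, and "the series" means these few. Any claim that something is new, unique, unknown or untested is made for them only; others in the source may bear on it.

Compound 1 `CCn1c(-c2ccccc2)nc2c(NC3CCC3)ncnc21` gives 84 nM in an assay on CHO cells for displacement of a labelled ligand from adenosine receptor A3 (Homo sapiens), read by scintillation counting, with a stated time of 3 h; on this read-out higher numbers stand for weaker inhibition and lower numbers for stronger inhibition. Compound 2 `CCCn1c(-c2ccccc2)nc2c(NC3CCC3)ncnc21` gives 264 nM in this assay, the higher of the two numbers, separated by a 3.1-fold higher number from compound 1 to compound 2 (0.50 log units; beyond the scatter). Compound 3 `CCCn1c(-c2ccccc2)nc2c(NC3CCCC3)ncnc21` carries the change (cyclopentyl in place of cyclobutyl on a nitrogen on an aromatic ring). Going by the values given here, the single measured step concerns the chain on the ring nitrogen and leaves the cyclobutyl untouched, so it does not bear on this change; nothing measured does. Within what is known, no step beyond the scatter in either direction is expected. Compound 3 is estimated at 200 nM, range 60 nM to 700 nM. The expected step is a 1.3-fold lower number from compound 2 to compound 3 (0.12 log units; within the scatter).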

Compound 3, inhibition constant: 749 nM
Estimate against measurement, compound 3: 3.7-fold (0.57 log units) below, and the stated range ends below it.
By their numbers in this assay, from the lowest: compound 1; then compound 2; then compound 3.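

With everything else in compound 2 held constant, cyclopentyl in place of cyclobutyl on a nitrogen on an aromatic ring gives a 2.8-fold higher number from compound 2 to compound 3 (0.45 log units; beyond the scatter) in this assay. Going by these compounds alone, this is the first measured change at this position, and it shows that the read-out responds to ring size here, with the larger ring on the weaker side. No evidence on the cause of this step is at hand. Still open, going by these compounds, is whether cyclopropyl or cyclohexyl on this nitrogen would extend the direction, and whether cyclopentyl gives a comparable step with the shorter chain of compound 1.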